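The compounds below may be only part of what the source reports. "The series", "measured", "known", "first", "only" and "open" are said of these compounds alone.

Three compounds of one series have been run in an ADME assay on the whole organism with Oryza sativa as the target, tested at 1 uM; a lower number here means a stronger effect, a higher number a weaker effect of the compound at the concentration tested. Compound 1 `Cc1ccc(NC(=O)N[C@@H](C)c2ccccc2)cc1` gives 99%. Compound 2 `C[C@H](NC(=O)Nc1ccc(F)cc1)c1ccccc1` gives 97%. Compound 3 `C[C@@H](NC(=O)Nc1ccc(F)cc1F)c1ccccc1` gives 100%. The difference between the cores of compound 2 and compound 3 is not broken down here. The change methyl in place of fluoro on an aromatic carbon gave a step of a number 2 percentage points higher from compound 2 to compound 1 (within the scatter). Compound 4 `Cc1cc(F)ccc1NC(=O)N[C@H](C)c1ccccc1` carries the same kind of change, (methyl in place of fluoro on an aromatic carbon), here set ortho to a large group and meta to a fluoro group rather than para to a large group. Because the earlier step of a number 2 percentage points higher from compound 2 to compound 1 (within the scatter) sat within the scatter, and all three measured numbers sit near the top of the read-out, the step expected for this change is a number 1 percentage points lower from compound 3 to compound 4 (within the scatter). Compound 4 is therefore estimated at 99%, with a likely range of 93% to 100%.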

Compound 4, a percentage reported as activity, at one concentration (the size of the read-out at that concentration, not a potency): 100%
Compound 4: the middle estimate sits 1 percentage points below what was measured; measured number inside the range.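

The step of no change at the digits printed from compound 3 to compound 4 (within the scatter) comes with methyl in place of fluoro on an aromatic carbon, here ortho to a large group and meta to a fluoro group, in this assay on this core. All the numbers sit near the top of the read-out, so this agreement does not show that the change would stay as small on a core with a stronger effect. On the two cores at hand, the steps do not differ: the same change on two cores in this assay, a number 2 percentage points higher (within the scatter) from compound 2 to compound 1 and no change at the digits printed (within the scatter) from compound 3 to compound 4, 2 percentage points apart, within the scatter of two such steps

The compounds shown leave open how the series responds to other groups on the aromatic ring, such as an amine or a carboxylic acid. They also leave open what a longer chain would do in place of the methyl.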